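Fluorine Pattern on the Benzyl Arm of Compound 3

The compounds below may be only part of what the source reports. "The series", "measured", "known", "first", "only" and "open" are said of these compounds alone.

The measured compounds and their values in a functional assay on Bel-7402 cells (Homo sapiens) for antiproliferative activity, read by MTT assay, with a stated time of 72 h (a lower number here means a stronger inhibitor, a higher number a weaker inhibitor), are these. Compound 1 `C=C1C(=O)O[C@H]2[C@H]1CC/C(Cn1cc(Cn3cc(F)c(=O)n(Cc4ccccc4)c3=O)nn1)=C\CC[C@@]1(C)O[C@@H]21` gives 9160 nM. Compound 2 `C=C1C(=O)O[C@H]2[C@H]1CC/C(COC(=O)CCC(=O)N1CCN(C(=O)Cn3cc(F)c(=O)n(Cc4ccccc4)c3=O)CC1)=C\CC[C@@]1(C)O[C@@H]21` reaches only a limit of the assay, > 20000 nM, and no number. Compound 3 `C=C1C(=O)O[C@H]2[C@H]1CC/C(COC(=O)Cn1cc(F)c(=O)n(Cc3ccc(F)cc3)c1=O)=C\CC[C@@]1(C)O[C@@H]21` gives 2730 nM.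

Among the two numbers, compound 3 stands lowest; its nearest neighbour is compound 1, whose number is higher by a gap that lies beyond the usual scatter. Compound 2 sits at the limit of > 20000 nM in this assay, at which 1 of the 3 values shown sits, and is only told as that limit. All three share the same core, and they differ only in the arm that carries the fluorinated pyrimidinedione; compound 3 holds it through a short ester link and a 4-fluorobenzyl group.

Compound 4 `C=C1C(=O)O[C@H]2[C@H]1CC/C(COC(=O)Cn1cc(F)c(=O)n(Cc3cc(F)ccc3F)c1=O)=C\CC[C@@]1(C)O[C@@H]21` keeps everything of compound 3 except the substitution on that benzyl ring: 2,5-difluorophenyl in place of 4-fluorophenyl on a saturated chain carbon bound to an aromatic nitrogen. Among the measured compounds shown here, no measured pair in this set shows what a second fluorine on this ring does, so nothing here argues for a large move in either direction. The step from compound 3 is expected to be small, within the scatter, so that a 1.0-fold lower number from compound 3 to compound 4 (0.00 log units; within the scatter) is the estimate. Compound 4 is therefore expected to give about 2700 nM in this assay, between 1100 nM and 6500 nM.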

Compound 4, half-maximal inhibitory concentration: 3060 nM
Beside the measured number, compound 4's estimate is 1.1-fold (0.05 log units) below it, and the stated range covers the measured number.
By their numbers in this assay, from the lowest: compounds 3 and 4 (each within the scatter of the next); then compound 1. At a limit, above all of these: compound 2.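

In this assay, among the compounds shown here, the exchange of 4-fluorobenzyl for 2,5-difluorobenzyl gives a 1.1-fold higher number from compound 3 to compound 4 (0.05 log units; within the scatter) and this is the only measured pair in the set that differs in one place. The earlier compounds shown here differed in the whole arm carrying the fluorinated pyrimidinedione, so they could say nothing about the benzyl ring alone; here, on a saturated chain carbon bound to an aromatic nitrogen, 2,5-difluorophenyl and 4-fluorophenyl cannot be told apart, a reading that holds for this one pair only. Nothing in the data shown gives a cause for this outcome.

The compounds shown leave open whether this ring on the short ester link would read the same with a methoxy group, a nitrile or an amine in place of fluorine, or with no substituent at all. Compound 1 and compound 2 do carry an unsubstituted benzyl group, but on other links, so what fluorine alone contributes at this position cannot be read from them.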